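Aryl swap on the aromatic nitrogen: compound 3 to compound 4

A few compounds are considered here, and "the series" means these few. Any claim that something is new, unique, unknown or untested is made for them only; others in the source may bear on it.

Measured so far in an ADME assay on HUVEC cells (Homo sapiens) for antiproliferative activity, read by MTT assay, with a stated time of 48 h; a lower number here means a stronger inhibitor, a higher number a weaker inhibitor:
- compound 1 `N#CC1=C(N)Oc2c(c3nc4ccccc4nc3c3ccccc23)C12C(=O)N(Cc1cnnn1-c1ccccc1Br)c1ccccc12`: > 50000 nM, a limit
- compound 2 `Cc1ccc(Cl)cc1-n1nncc1CN1C(=O)C2(C(C#N)=C(N)Oc3c2c2nc4ccccc4nc2c2ccccc32)c2ccccc21`: > 50000 nM, a limit
- compound 3 `N#CC1=C(N)Oc2c(N)cc3nc4ccccc4nc3c2C12C(=O)N(Cc1cnnn1-c1ccccc1Cl)c1ccccc12`: > 50000 nM, a limit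

All three values in this assay are limits, not numbers. Within the data shown here, the one step between measured compounds that differ in a single place, a step that the two limits leave unreadable from compound 1 to compound 2, has two limits at its ends and its size cannot be read. Among the measured compounds shown here, compound 3 therefore stands where every value so far stands: at the limit of > 50000 nM in this assay, at which 3 of the 3 values shown sit.

Compound 4 `Cc1ccc(C)c(-n2nncc2CN2C(=O)C3(C(C#N)=C(N)Oc4c(N)cc5nc6ccccc6nc5c43)c3ccccc32)c1` is the next compound. It differs from compound 3 as follows: 2,5-dimethylphenyl in place of 2-chlorophenyl on an aromatic nitrogen. For the measured compounds named here, the only measured step at this same aromatic nitrogen, a step that the two limits leave unreadable from compound 1 to compound 2, bears on this change but gives no size because both of its ends sit at the limit of > 50000 nM in this assay, at which 3 of the 3 values shown sit. Going by the values given here, no other pair speaks to this position.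

With nothing in the data that moves any compound off the limit, compound 4 is expected to remain at the limit as well, with an estimated value of 60000 nM (range 25000 nM to 200000 nM). The expected step that the limit leaves unreadable from compound 3 to compound 4 is none beyond the scatter.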

Compound 4, half-maximal inhibitory concentration: > 50000 nM
Compound 4: no number, only a limit (the forecaster's own chance of this, stated with the estimate: 85%); the middle value lies beyond the limit too.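

Compound 3 and compound 4 both sit at a limit, so the step between them cannot be read. All values shown stand at the same point: the limit of > 50000 nM in this assay, at which 4 of the 4 values shown sit.

The compounds shown leave open whether any aryl group on this aromatic nitrogen, or any change to the shared core, gives a measurable value in this assay.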